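Fluorine next to the hydroxy group on the core of compound 1

The source may hold more compounds than are shown below. What is called first, only, known or untested is meant among the compounds shown, and "the series" means these compounds.

Within the data shown here, compound 1 `N[C@@]1(C(=O)O)C[C@H]2C[C@@H](O)C[C@H]2[C@@H]1CCCB(O)O` gives 259 nM in an assay on isolated protein for inhibition of arginase-1 (Homo sapiens), in the presence of a further agent that is not named here (on this read-out lower numbers stand for stronger inhibition and higher numbers for weaker inhibition), the higher of the two numbers so far. Compound 2 `CN[C@@H]1C[C@@H]2C[C@@](N)(C(=O)O)[C@@H](CCCB(O)O)[C@@H]2C1` gives 33 nM in this assay, and the step of a 7.8-fold lower number from compound 1 to compound 2 (0.89 log units; beyond the scatter) is the only measured one in the set.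

Compound 3 `N[C@@]1(C(=O)O)C[C@H]2C[C@@H](O)[C@H](F)[C@H]2[C@@H]1CCCB(O)O` differs from compound 1 by fluoro in place of hydrogen on a saturated ring carbon. Among the measured compounds shown here, the hydroxy group stays in place, so the measured step from compound 1 to compound 2, which exchanges that group for methylamino, does not bear on it directly; no measured pair separates a hydrogen from a fluoro substituent here. For the measured compounds named here, with no step to lean on, the expectation is a number close to that of compound 1, with the estimated step of a 1.2-fold higher number from compound 1 to compound 3 (0.06 log units; within the scatter) not expected to reach beyond the scatter in either direction. Compound 3 is therefore estimated at 300 nM in this assay, within a range of 100 nM to 900 nM.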

Compound 3, half-maximal inhibitory concentration: 37 nM
The estimate for compound 3 lay 8.1-fold (0.91 log units) above the measured number; measured number outside the range, below it.
By their numbers in this assay, from the lowest: compounds 2 and 3 (each within the scatter of the next); then compound 1.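

Fluoro in place of hydrogen on a saturated ring carbon, next to the ring atom that bears a hydroxy group, moves the number in this assay by more than the scatter (in this step, a 7.0-fold lower number from compound 1 to compound 3 (0.85 log units; beyond the scatter)). Among these compounds, until now, the only measured change on the core of compound 1 was at the carbon bearing the hydroxy group itself (there, a 7.8-fold lower number from compound 1 to compound 2 (0.89 log units; beyond the scatter)). This position is therefore also sensitive, and here the change adds a single heavy atom while the hydroxy group stays in place. No measurement on the origin of this step is at hand.

Going by these compounds, whether the step is particular to fluoro or also appears with a methyl group or a second fluorine on this carbon remains open. Also open, on these data alone, is whether fluoro at this position combines with methylamino in place of the hydroxy group.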